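Defining the ring stereocentre of a piperidine-bearing glycine transporter inhibitor

This account rests on a few compounds, and the source may have more. Where it says the series, first, only, none or still open, it means among the compounds named here.

Measured so far:
- compound 1 `O=S(=O)(NC[C@H](O)CN1CCCC1C1CCCCC1)c1cccc2ccccc12`: 6310 nM; 6310 nM (2 entries)
- compound 2 `CCC1CCCCN1C[C@@H](O)CNS(=O)(=O)c1cccc2ccccc12`: 7940 nM

In an assay on HEK293 cells for inhibition of sodium- and chloride-dependent glycine transporter 1 (Homo sapiens) (on this read-out lower numbers stand for stronger inhibition and higher numbers for weaker inhibition), compound 1 gives 6310 nM; 6310 nM (2 entries), recorded twice with the same result. In this assay compound 2 gives 7940 nM; this is the one number shown for compound 2, alongside a further entry for which no single number is given. The values of compound 1 and compound 2 lie within the usual scatter of each other, so nothing can be said about an order between them.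

The account follows the step from compound 2 to compound 3 `CC[C@H]1CCCCN1C[C@@H](O)CNS(=O)(=O)c1cccc2ccccc12`. The two differ only in this respect: the two compounds have the same atoms and bonds; at least one stereo element is drawn with a configuration in one of them and without one in the other: 1 of 2 stereo elements differ; a stereocentre at a saturated ring carbon is drawn without a configuration in compound 2 and S in compound 3. Compound 2 is thus drawn as a mixture at the ring carbon, while compound 3 is the single isomer with the S configuration there. Among the measured compounds shown here, no measured pair shows what resolving such a centre does here. Because compound 2 gives 7940 nM as a mixture, compound 3 is expected to land near it, with the step of a 1.6-fold lower number from compound 2 to compound 3 (0.20 log units; within the scatter) estimated to stay within the scatter, or at most a modest gain. Compound 3 is therefore expected to give 5000 nM, within a range of 2000 nM to 16000 nM.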

Compound 3, half-maximal inhibitory concentration: 100 nM
Estimate against measurement, compound 3: 50-fold (1.70 log units) above, outside the stated range (below it).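

Drawing the ring carbon as the single S isomer changes the read-out sharply even though no atom or bond is altered: in this assay the change gives a 79-fold lower number from compound 2 to compound 3 (1.90 log units; beyond the scatter). Compound 1 and compound 2 are both drawn without a configuration at their ring carbon, so neither could show that the configuration there matters so strongly, or that a compound with a number as low as that of compound 3 lay behind such a drawing. The large step is therefore tied to a single difference between the two structures: the fact that one of compounds 2 and 3 is drawn with a defined configuration and the other without, at the place where they differ

The compounds shown leave open how the isomer with the R configuration at this ring carbon behaves, and the value of compound 2 does not reveal which isomers it contains or in what proportion. They also leave open whether defining the ring carbon of compound 1 would bring a comparable step, and whether the S configuration would give a similar number with a longer chain or a phenyl group on that ring carbon.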